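The source may report more compounds than this note shows. Statements on the series, on what has been measured and on what is new or still open speak of the compounds shown alone.

Values measured so far in a functional assay on MCF7 cells (Homo sapiens) for antiproliferative activity, read by MTT assay, with a stated time of 72 h (on this read-out higher numbers stand for weaker inhibition and lower numbers for stronger inhibition), are these:
compound 1 `COc1ncc(-c2ccc3c(c2)N(c2ccc(C)cc2)C(=O)CO3)cc1NS(=O)(=O)c1ccc(F)cc1` gives 15400 nM
compound 2 `O=C1COc2ccc(-c3cccc(NS(=O)(=O)c4ccc(F)cc4)c3)cc2N1` gives 18300 nM
compound 3 `COc1ccc(N2C(=O)COc3ccc(-c4ccc(O)cc4)cc32)cc1` gives 17300 nM

Compound 1 stands level with the other two: its number lies within the scatter of both compound 2 and compound 3, and the three values read as a single band. Still unmeasured is compound 4 `COc1ncc(-c2ccc3c(c2)N(C2CCCCC2)C(=O)CO3)cc1NS(=O)(=O)c1ccc(F)cc1`, which keeps the core of compound 1. It carries cyclohexyl in place of 4-methylphenyl on an amide-type nitrogen in a ring and nothing else is altered. Among the compounds with values here, no pair of measured compounds isolates this change, so the data offer no direct guide to it. The only indirect hint comes from compound 2, which has the amide hydrogen on that nitrogen and differs elsewhere as well. Compound 2 gives 18300 nM and so sits in the same band as compound 1, which suggests that the number may not depend strongly on the group at this place. In this assay no step beyond the scatter is therefore expected, in either direction. The estimate amounts to an expected step of a 1.0-fold higher number from compound 1 to compound 4 (0.02 log units; within the scatter) and no more. For compound 4 the estimated value is 16000 nM with an expected range from 7000 nM to 36000 nM on this read-out.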

Compound 4, half-maximal inhibitory concentration: 30100 nM
For compound 4 the middle estimate is 1.9-fold (0.27 log units) below the measured one, and the stated range covers the measured number.
By their numbers in this assay, from the lowest: compounds 1, 3, 2 and 4 (each within the scatter of the next).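

In this assay, within the data shown here, exchanging 4-methylphenyl for cyclohexyl on the amide-type nitrogen in a ring gives a 2.0-fold higher number from compound 1 to compound 4 (0.29 log units; within the scatter), the first direct reading at this position. On the core of compound 1, an aromatic ring of carbon only and a non-aromatic ring of carbon only at this nitrogen therefore cannot be told apart on this read-out, although the step lies close to the edge of the scatter and rests on a single pair. Nothing available explains this result or shows why the two rings read alike.

The compounds shown cover only these two ring groups on the shared core, and compound 2, which has the amide hydrogen on this nitrogen, differs elsewhere as well, so the step to the unsubstituted nitrogen cannot be read. As far as these compounds go, whether the number would stay in the same band with a short chain such as ethyl, or with a chain ending in an amine or a carboxylic acid on this nitrogen, remains open.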